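The source may hold more compounds than are shown below. What is called first, only, known or untested is meant among the compounds shown, and "the series" means these compounds.

Compound 1 `Cc1nn2c(C(C)c3ccc(CC(C)C)cc3)nnc2s1` gives 62% in a functional assay on the whole organism (strain Wistar albino) for inhibition, with Rattus norvegicus as the target, read by paw edema, with stated times of 30 min and 3 h, at a dose of 20 mg/kg by the oral route; a lower number here means less inhibition, a higher number more inhibition at the dose given (going by the name of the read-out).
Compound 2 `CCc1nn2c(C(C)c3ccc(CC(C)C)cc3)nnc2s1` gives 55% in this assay.

Within the data shown here, of these two numbers, compound 2 has the smaller, with compound 1 as its only neighbour, and the step of a number 7 percentage points lower from compound 1 to compound 2 (within the scatter) is one that repeated measurements could produce on their own. That step, where methyl replaces hydrogen on a saturated chain carbon bound to an aromatic carbon, is the same kind of change as the one now in question, only one bond further out.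

Compound 3 `CCCc1nn2c(C(C)c3ccc(CC(C)C)cc3)nnc2s1` differs from compound 2 by methyl in place of hydrogen on a saturated chain carbon, two bonds along the chain from an aromatic carbon. Among the measured compounds shown here, since the only measured step of this kind, a number 7 percentage points lower from compound 1 to compound 2 (within the scatter), stayed within the scatter, no shift beyond the scatter is expected in this assay here either. Compound 3 is therefore expected to give about 50%, within a range from 38% to 62%, which means an estimated step of a number 5 percentage points lower from compound 2 to compound 3 (within the scatter).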

Compound 3, a percentage reported as inhibition, in the whole organism at one dose (the size of the read-out at that dose, not a potency): 34%
Estimate against measurement, compound 3: 16 percentage points above; the whole stated range lies above it.
By their numbers in this assay, from the lowest: compound 3; then compounds 2 and 1 (each within the scatter of the next).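

In this assay the change from ethyl to propyl gives a number 21 percentage points lower from compound 2 to compound 3 (beyond the scatter) and so shows that this chain can affect the read-out, whereas the change from methyl to ethyl gave a number 7 percentage points lower from compound 1 to compound 2 (within the scatter) and could not be told apart from repeated-measurement noise. Taken together, the two changes give a number 28 percentage points lower from compound 1 to compound 3 (beyond the scatter) and show that, among these three compounds, the longest chain at this position goes with the least inhibition at the dose given. Nothing available here explains why the number falls at this step.

The compounds shown leave open whether a butyl chain would lower the number further or whether the effect depends on length alone. They also leave open how a branched isopropyl group or an amine at this position would compare with propyl.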